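Variation of the Urea Partner Toward Compound 4

The source may hold more compounds than are shown below. What is called first, only, known or untested is meant among the compounds shown, and "the series" means these compounds.

Compound 1 `COc1ccc(OC2CN(C(=O)NC3CCN(Cc4ccn(-c5ccc(C(F)(F)F)cc5)c4)CC3)C2)cc1`: 49 nM
Compound 2 `O=C(NC1CCN(Cc2ccn(-c3ccc(C(F)(F)F)cc3)c2)CC1)N1CCCC1Cc1cccnc1`: 26 nM
Compound 3 `CN1CCN(C(=O)NC2CCN(Cc3ccn(-c4ccc(C(F)(F)F)cc4)c3)CC2)C(c2ccccc2)C1`: 28 nM

In an assay on HEK293 cells for displacement of a labelled ligand from melanin-concentrating hormone receptor 1 (Homo sapiens) (a higher number here means a weaker inhibitor, a lower number a stronger inhibitor), compound 2 gives 26 nM, the lowest of the three numbers, while compound 3 gives 28 nM and compound 1 gives 49 nM; both differences from compound 2 lie within the scatter, so no ranking among the three is established. Compound 4 `O=C(NCC1(O)CCCCC1)NC1CCN(Cc2ccn(-c3ccc(C(F)(F)F)cc3)c2)CC1` differs from compound 2 in a single place: ((1-hydroxycyclohexyl)methyl)amino in place of 2-((pyridin-3-yl)methyl)pyrrolidin-1-yl on a carbonyl carbon. No measured pair among these compounds shows a change of this kind, so the expectation rests only on compound 2 and its value of 26 nM. The estimated step is a 4.2-fold higher number from compound 2 to compound 4 (0.63 log units; beyond the scatter), a weakening expected to go beyond the scatter. Compound 4 is therefore expected at 110 nM, with a range from 30 nM to 450 nM.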

Compound 4, half-maximal inhibitory concentration: 44 nM
Estimate against measurement, compound 4: 2.5-fold (0.40 log units) above; the range from low to high includes it.
By their numbers in this assay, from the lowest: compounds 2, 3, 4 and 1 (each within the scatter of the next).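

In this assay, going by these compounds alone, the one pair differing at this place gives a 1.7-fold higher number from compound 2 to compound 4 (0.23 log units; within the scatter). On this carbonyl carbon, then, 2-((pyridin-3-yl)methyl)pyrrolidin-1-yl, with its aromatic ring, can give way to ((1-hydroxycyclohexyl)methyl)amino, with a ring of carbon only and hydrogen-bond donors where the leaving group has none, with no change distinguishable from the scatter. Nothing shown offers a reason for this outcome. Still open, on these data alone, is whether the hydroxyl of compound 4 matters at all. A methoxy group or a primary amine in its place would address that.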